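Chain length and acyl-CoA:cholesterol acyltransferase inhibition in carbamoyl carbamates

This account rests on a few compounds, and the source may have more. Where it says the series, first, only, none or still open, it means among the compounds named here.

Measured compounds:
Compound 1, `CCCCCCCCCCCOC(=O)NC(=O)Oc1c(C(C)C)cccc1C(C)C`, in an assay on microsomes from intestine for inhibition of acyl-CoA:cholesterol acyltransferase (Oryctolagus cuniculus) (on this read-out lower numbers stand for stronger inhibition and higher numbers for weaker inhibition), gives 140 nM.
Compound 2, `CCCCCCCCCCCCCOC(=O)NC(=O)Oc1c(C(C)C)cccc1C(C)C`, in this assay gives 9 nM.
Compound 3, `CCCCCCCCCCCCCCCCOC(=O)NC(=O)Oc1c(C(C)C)cccc1C(C)C`, in this assay gives 50 nM.

All three share one core and differ only in the length of the saturated chain. Compound 1 to compound 2 is the change (ethyl in place of hydrogen on a saturated chain carbon, ten or more bonds along the chain from an oxygen next to a carbonyl group); the step is a 16-fold lower number from compound 1 to compound 2 (1.19 log units; beyond the scatter). Compound 1 to compound 3 is the change (pentyl in place of hydrogen on a saturated chain carbon, ten or more bonds along the chain from an oxygen next to a carbonyl group); the step is a 2.8-fold lower number from compound 1 to compound 3 (0.45 log units; beyond the scatter). From compound 2 to compound 3 the step is a 5.6-fold higher number from compound 2 to compound 3 (0.74 log units; beyond the scatter), so the numbers do not fall steadily with chain length: compound 2 stands lowest and compound 3 sits between compound 1 and compound 2.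

Compound 4, `CCCCCCCCCCCCCCCCCCOC(=O)NC(=O)Oc1c(C(C)C)cccc1C(C)C`, is not yet measured. From compound 3 it differs by ethyl in place of hydrogen on a saturated chain carbon, ten or more bonds along the chain from an oxygen next to a carbonyl group, the same change as from compound 1 to compound 2, at the same place on the chain. The earlier instance gave a large step lower, but that gain was already partly lost again between compound 2 and compound 3, so a repeat of that step is not expected here. Compound 4 is expected to give about 110 nM in this assay, between 35 nM and 400 nM. The estimated step of a 2.2-fold higher number from compound 3 to compound 4 (0.34 log units; beyond the scatter) rests on compound 3 at 50 nM and on the turn seen in a 5.6-fold higher number from compound 2 to compound 3 (0.74 log units; beyond the scatter), which suggests the series has passed its best chain length; only compound 2 and compound 3 support that turn.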

Compound 4, half-maximal inhibitory concentration: 1000 nM
Estimate against measurement, compound 4: 9.1-fold (0.96 log units) below; measured number above the stated range.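

Ethyl in place of hydrogen on a saturated chain carbon does not carry over as a fixed increment in this assay: the new instance is a 20-fold higher number from compound 3 to compound 4 (1.30 log units; beyond the scatter), opposite in direction to the earlier one on the shorter chain: the same change on two cores in this assay, a 16-fold lower number (1.19 log units; beyond the scatter) from compound 1 to compound 2 and a 20-fold higher number (1.30 log units; beyond the scatter) from compound 3 to compound 4, 310-fold (2.49 log units) apart, beyond the scatter of two such steps

Pentyl in place of hydrogen shows the same dependence on the starting chain, with a 110-fold higher number from compound 2 to compound 4 (2.05 log units; beyond the scatter), and heptyl gives a 7.1-fold higher number from compound 1 to compound 4 (0.85 log units; beyond the scatter), so compound 4 carries the highest number of the four and the weakest inhibition: the same change on two cores in this assay, a 2.8-fold lower number (0.45 log units; beyond the scatter) from compound 1 to compound 3 and a 110-fold higher number (2.05 log units; beyond the scatter) from compound 2 to compound 4, 310-fold (2.49 log units) apart, beyond the scatter of two such steps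

The size and direction of a chain extension in this series therefore depend on the chain it starts from, but each step rests on a single pair of compounds, and these data do not show why the direction reverses.

The compounds shown leave open how the numbers run at chain lengths other than these four, and whether the sharp rise at compound 4 continues with a still longer chain. They also leave open whether a branched chain, or a chain ending in a carboxylic acid or an amine, would follow the same course on the shared core.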